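The compounds below may be only part of what the source reports. "The series", "measured", "known", "first", "only" and "open" are said of these compounds alone.

Measured so far in an ADME assay on MDBK cells (Bos taurus) for cytotoxicity, read by MTT assay, with a stated time of 96 h; on this read-out higher numbers stand for lower toxicity in this test and lower numbers for higher toxicity in this test:
- Compound 1 `CC(=O)c1ccc2c(c1)nc(-c1ccoc1)n2C1CCCCC1`: > 100000 nM (a limit)
- Compound 2 `C/C(=N\NC(N)=O)c1ccc2c(c1)nc(-c1ccoc1)n2C1CCCCC1`: > 100000 nM (a limit)
- Compound 3 `COc1ccc(-c2nc3cc(/C(C)=N/NC(N)=S)ccc3n2C2CCCCC2)cc1`: 32000 nM

Among the compounds with values here, compound 3 gives 32000 nM, the only number in the set. Compound 4 `C/C(=N\NC(N)=S)c1ccc2c(c1)nc(-c1ccoc1)n2C1CCCCC1` is not yet measured. Its change from compound 3 is furan-3-yl in place of 4-methoxyphenyl on an aromatic carbon.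

Within the data shown here, no measured step isolates this change. Among the measured compounds shown here, the one step available, a step that the two limits leave unreadable from compound 1 to compound 2, gives no size. Compound 1 and compound 2, which both carry furan-3-yl, sit at the limit of > 100000 nM in this assay, at which 2 of the 3 values shown sit. This is thin support, but it points towards lower toxicity in this test. A moderate rise is therefore expected in this assay, and the estimated step is a 1.9-fold higher number from compound 3 to compound 4 (0.27 log units; within the scatter). For compound 4 the expected value is 60000 nM, with an estimated range of 22000 nM to 100000 nM.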

Compound 4, half-maximal cytotoxic concentration: > 100000 nM
Compound 4 gave a limit, no number; the forecaster's own chance of this, stated with the estimate: 40%; at least 1.6-fold (0.22 log units) between middle value and limit.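

In this assay, within the data shown here, furan-3-yl in place of 4-methoxyphenyl on this aromatic carbon, between two ring nitrogen atoms, gives the first readable step at this position: an at least 3.1-fold higher number from compound 3 to compound 4 (0.49 log units; beyond the scatter). The size of this step is open at its upper end, as compound 4 gives only a limit. The steps among compound 1, compound 2 and compound 4 cannot be read, as all three sit at the same limit: the limit of > 100000 nM in this assay, at which 3 of the 4 values shown sit.

Going by these compounds, how far the furan-3-yl compounds lie beyond that limit remains open. So does how an unsubstituted phenyl or a thiophene ring would read at this position.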